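Replacing propoxy with hexylsulfanyl on the shared core

The source may hold more compounds than are shown below. What is called first, only, known or untested is meant among the compounds shown, and "the series" means these compounds.

Compound 3 `CCCOc1nc(N)nc2c1ncn2/C=C1/CC1(CO)CO` is where the series currently stands. In an ADME assay on BCBL1 cells (Homo sapiens) for cytotoxicity, with a stated time of 7 days (a higher number here means that more compound is tolerated, a lower number that less compound is tolerated), compound 3 gives > 20000 nM, which is a limit of the assay and not a number. Compound 1 `Nc1nc(NC2CCCCC2)c2ncn(/C=C3/CC3(CO)CO)c2n1` shares the core. In this assay compound 1 gives > 20000 nM, again a limit. Compound 2 `Nc1nc(NC2CC2)c2ncn(/C=C3/CC3(CO)CO)c2n1` carries cyclopropylamino in place of cyclohexylamino. In this assay compound 2 gives 71500 nM.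

The measured steps are a step that the limit leaves unreadable from compound 1 to compound 2, a step that the two limits leave unreadable from compound 1 to compound 3 and a step that the limit leaves unreadable from compound 2 to compound 3; none yields a readable size, since (the limit of > 20000 nM in this assay, at which 2 of the 3 values shown sit).

Compound 4 `CCCCCCSc1nc(N)nc2c1ncn2/C=C1/CC1(CO)CO` is not yet measured. It differs from compound 3 by hexylsulfanyl in place of propoxy on an aromatic carbon. Among the measured compounds shown here, no measured step touches this change, and the cyclohexylamino and propoxy analogues both sit at the limit, so no direction can be read for compound 4 in this assay; a result at or near that limit is the expectation, with the step from compound 3 to compound 4 estimated as a step that the limit leaves unreadable from compound 3 to compound 4. Compound 4 is therefore expected to give about 30000 nM in this assay, within 10000 nM to 100000 nM.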

Compound 4, half-maximal cytotoxic concentration: > 20000 nM
Compound 4 was reported as a limit; the forecaster's own chance of this, stated with the estimate: 60%; the middle value does not contradict the limit.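

None of the steps joining compound 4 to compound 1, compound 2 or compound 3 in this assay can be read: the limit of > 20000 nM in this assay, at which 3 of the 4 values shown sit.

The compounds shown leave open whether hexylsulfanyl in place of propoxy on the shared core changes how much compound is tolerated in this assay.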